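The compounds below may be only part of what the source reports. "The series", "measured", "known", "first", "only" and "open" are said of these compounds alone.

Measured compounds:
- compound 1 `c1cncc(-c2ccccc2OCC2=NCCN2)c1`: 257 nM
- compound 2 `c1c[nH]c(-c2ccccc2OCC2=NCCN2)c1`: 53.7 nM

Going by the values given here, in an assay on cell membranes for binding affinity to Alpha-1D adrenergic receptor (Homo sapiens) (on this read-out lower numbers stand for stronger inhibition and higher numbers for weaker inhibition), compound 2 has the lowest of the two numbers; the only neighbour is compound 1, and the move from it is a 4.8-fold lower number from compound 1 to compound 2 (0.68 log units; beyond the scatter), a shift beyond the scatter but of modest size. Compound 3 `Cc1ccoc1-c1ccccc1OCC1=NCCN1` is not yet measured. Its change from compound 2 is 3-methylfuran-2-yl in place of 1H-pyrrol-2-yl on an aromatic carbon. Among the compounds with values here, no measured step reproduces this change exactly: the one step on record swaps a six-membered nitrogen ring for a five-membered one carrying a donor, whereas here a five-membered ring with a donor gives way to a five-membered ring with an acceptor and a methyl. The ring geometry stays close, so a large move in either direction seems unlikely; the loss of the donor is weighed as a moderate disadvantage. Compound 3 is therefore expected at 110 nM in this assay, within 35 nM to 350 nM, meaning a step of a 2.0-fold higher number from compound 2 to compound 3 (0.31 log units; beyond the scatter).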

Compound 3, half-maximal inhibitory concentration: 417 nM
Compound 3: middle estimate off by 3.8-fold (0.58 log units), on the low side; the whole stated range lies below it.
By their numbers in this assay, from the lowest: compound 2; then compounds 1 and 3 (each within the scatter of the next).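

In this assay, 3-methylfuran-2-yl in place of 1H-pyrrol-2-yl on this aromatic carbon gives a 7.8-fold higher number from compound 2 to compound 3 (0.89 log units; beyond the scatter), so the low number of compound 2 does not extend to every five-membered aromatic ring with one hetero atom at this position. The 3-methylfuran-2-yl and pyridin-3-yl groups are not told apart here, with a 1.6-fold higher number from compound 1 to compound 3 (0.21 log units; within the scatter), which leaves compound 2 as the only one of the three standing apart. Nothing available accounts for the size of the step.

Still open, on these data alone, is whether the ring oxygen or the added methyl carries the step, as the two enter together; an unsubstituted furan-2-yl and a methyl-bearing 1H-pyrrol-2-yl group would separate them. Also open, as far as these compounds go, is how an amine or a carboxylic acid on the pyrrole ring would read.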